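The source may hold more compounds than are shown below. What is called first, only, known or untested is meant among the compounds shown, and "the series" means these compounds.

Of the compounds shown here, three have been measured in a functional assay on DU-145 cells (Homo sapiens) for cytotoxicity, read by MTT assay, with a stated time of 48 h; a lower number here means a stronger inhibitor, a higher number a weaker inhibitor. Compound 1 `COc1cc(-c2cc(COCc3cn(Cc4cc(-c5ccc(F)cc5)cnc4Cl)nn3)on2)cc(OC)c1OC` gives 31900 nM. Compound 2 `COc1cc(C2=NOC(COCc3cn(Cc4cc(-c5ccccc5)cnc4Cl)nn3)C2)cc(OC)c1OC` gives 11400 nM, and compound 3 `COc1cc(C2=NOC(COCc3cn(Cc4cc(-c5ccc(C)cc5)cnc4Cl)nn3)C2)cc(OC)c1OC` gives 13100 nM. Compound 3 therefore stands second highest of the three numbers: its value sits within the scatter of compound 2, while compound 1 has a higher number than compound 3 by more than the scatter.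

Compound 4 `COc1cc(C2=NOC(COCc3cn(Cc4cc(C)cnc4Cl)nn3)C2)cc(OC)c1OC` differs from compound 3 in one place, (methyl in place of 4-methylphenyl on an aromatic carbon). Within the data shown here, the only measured step touching this part of the molecule is the one from compound 2 to compound 3, a 1.1-fold higher number from compound 2 to compound 3 (0.06 log units; within the scatter), in which a methyl was added to the very ring that compound 4 loses entirely. That step lay within the scatter, so it shows that decorating the ring hardly matters, but it says nothing direct about removing the 4-methylphenyl group as a whole. Among the measured compounds shown here, no measured pair tests such a removal, so the direction of the step is uncertain, and a modest rise in the number seems as likely as no change. Compound 4 is therefore expected to give about 25000 nM, within a range from 8000 nM to 80000 nM, meaning an expected step of a 1.9-fold higher number from compound 3 to compound 4 (0.28 log units; within the scatter).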

Compound 4, half-maximal inhibitory concentration: 58900 nM
Compound 4: middle estimate off by 2.4-fold (0.37 log units), on the low side, and the stated range covers the measured number.
By their numbers in this assay, from the lowest: compounds 2 and 3 (each within the scatter of the next); then compounds 1 and 4 (each within the scatter of the next).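

In this assay, putting methyl in place of 4-methylphenyl on this aromatic carbon, two atoms from the ring nitrogen, gives a 4.5-fold higher number from compound 3 to compound 4 (0.65 log units; beyond the scatter), and putting methyl in place of phenyl gives a 5.2-fold higher number from compound 2 to compound 4 (0.71 log units; beyond the scatter); both steps lie beyond the scatter, so these methyl-for-ring changes weaken the compound. The earlier step, a 1.1-fold higher number from compound 2 to compound 3 (0.06 log units; within the scatter), showed only that adding a methyl to the outer ring makes no clear difference, whereas these new steps show that this position is not indifferent to what it carries: with a six-membered aromatic ring of carbon there, the number is clearly lower than with a methyl alone. No measurement available here explains this loss of activity.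

The compounds shown cannot separate the effect of having an aromatic ring at this position from that of simply having a larger group, and a cyclohexyl group or a longer chain such as butyl would be needed to tell those two apart. They also leave open how an amine or a carboxylic acid would fare on this carbon, and whether a bare hydrogen there would match the methyl of compound 4.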